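The source may report more compounds than this note shows. Statements on the series, on what has been measured and on what is new or still open speak of the compounds shown alone.

Measured compounds:
Compound 1, `O=S(=O)(c1cc(F)cc(F)c1)c1cnc2cc(F)ccc2c1-c1ccc(Cl)cc1`, gives 0.03 mL/min.
Compound 2, `COc1ccc(S(=O)(=O)c2cnc3cc(F)ccc3c2-c2cccc(F)c2)cc1Cl`, gives 2.08 mL/min.

Both values come from an ADME assay on microsomes from liver (Homo sapiens) for metabolic stability, tested at 2.5 uM; on this read-out lower numbers stand for slow clearance and higher numbers for fast clearance. Among the measured compounds shown here, of the two numbers in this assay, compound 2 stands highest, and its only neighbour, compound 1, sits well below it, a gap that lies beyond the usual scatter of the method.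

Compound 3, `O=S(=O)(c1cc(F)cc(F)c1)c1cnc2cc(F)ccc2c1-c1cccc(F)c1`, has not yet been tested. It differs from compound 2 in one place: 3,5-difluorophenyl in place of 3-chloro-4-methoxyphenyl on a sulfonyl sulfur. The group that enters is the same one that sits on the sulfonyl sulfur in compound 1, while the rest of compound 3 matches compound 2.

For the measured compounds named here, no step between two measured compounds has been recorded, so the size of the change can only be expected, not read off. Since compound 1 gives 0.03 mL/min, the step of a 14-fold lower number from compound 2 to compound 3 (1.14 log units; beyond the scatter) is expected to be a decrease that reaches beyond the scatter. Compound 3 is expected to give 0.15 mL/min, with a range from 0.03 mL/min to 0.8 mL/min.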

Compound 3, intrinsic clearance in a liver preparation (reported as CLH), per the amount of preparation that the assay uses: 0.06 mL/min
Compound 3: the middle estimate sits 2.5-fold (0.40 log units) above what was measured; low and high end bracket the measured number.
By their numbers in this assay, from the lowest: compounds 1 and 3 (each within the scatter of the next); then compound 2.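

Among the compounds shown here, compound 3 gives the first measured one-place change on the sulfonyl sulfur in this assay and shows that this position strongly affects the read-out: the exchange of 3-chloro-4-methoxyphenyl for 3,5-difluorophenyl gives a 35-fold lower number from compound 2 to compound 3 (1.54 log units; beyond the scatter) and counts as a large step. The change on the aromatic carbon, 3-fluorophenyl in place of 4-chlorophenyl, gives a 2.0-fold higher number from compound 1 to compound 3 (0.30 log units; within the scatter) and stays within the scatter, so with 3,5-difluorophenyl on the sulfonyl sulfur this exchange does not separate the two compounds. Nothing available explains either result.

The compounds shown leave open whether the chlorine, the methoxy group or the two together account for the large step, since they leave as parts of one group. They also leave open whether the sulfonyl sulfur would keep such a low number with a pyridine ring, an aromatic ring bearing an amine or a carboxylic acid, or a longer alkyl chain in place of 3,5-difluorophenyl.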